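The source may hold more compounds than are shown below. What is called first, only, known or untested is meant among the compounds shown, and "the series" means these compounds.

Two compounds of this series carry a measurement so far. Compound 1 `O=C(/C=C/c1ccc([N+](=O)[O-])cc1)Nc1cc(-c2ccccc2)[nH]n1` pairs a nitrophenyl cinnamamide with an unsubstituted phenyl on the shared core; in a functional assay on MCF7 cells (Homo sapiens) for antiproliferative activity, read by MTT assay, with a stated time of 48 h (on this read-out lower numbers stand for stronger inhibition and higher numbers for weaker inhibition), compound 1 gives 630 nM. Compound 2 `O=C(/C=C/c1ccc(Cl)cc1)Nc1cc(-c2ccc(Br)cc2)[nH]n1` carries a chlorophenyl cinnamamide and a 4-bromophenyl on the same core; in this assay compound 2 gives 770 nM. Compound 2 thus holds the larger of the two numbers, with compound 1 nearest, but the gap between the two lies within the usual scatter, so they cannot be told apart on these data.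

Compound 3 `O=C(/C=C/c1ccc(Cl)cc1)Nc1cc(-c2ccccc2)[nH]n1` has not been measured. It differs from compound 2 in one place: hydrogen in place of bromo on an aromatic carbon. Among the compounds with values here, no measured pair isolates this change, so its size is unknown here. The two measured compounds differ at both aryl groups yet sit within the scatter of each other, which gives no sign that the series responds strongly to changes at the aryl on the core. The step from compound 2 to compound 3 in this assay is therefore expected to be small, a 1.0-fold higher number from compound 2 to compound 3 (0.02 log units; within the scatter), with no direction favoured beyond the scatter. For compound 3 an estimate of 800 nM is expected, with a range from 350 nM to 2000 nM.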

Compound 3, half-maximal inhibitory concentration: 970 nM
Estimate against measurement, compound 3: 1.2-fold (0.08 log units) below; measured number inside the range.
By their numbers in this assay, from the lowest: compounds 1, 2 and 3 (each within the scatter of the next).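

Hydrogen in place of bromo on the aromatic carbon para to a large group can now be read as a single change: in this assay it gives a 1.3-fold higher number from compound 2 to compound 3 (0.10 log units; within the scatter), so the 4-bromophenyl to phenyl change has no effect that can be told from the scatter in this pair. The second single change, chloro in place of nitro on an aromatic carbon of the cinnamamide aryl, gives a 1.5-fold higher number from compound 1 to compound 3 (0.19 log units; within the scatter), so the series now shows two single-place changes, at two different aryl groups, and neither separates its compounds on these numbers. No data at hand bear on the cause of either step.

The compounds shown cover only hydrogen and bromo at the first place and only nitro and chloro at the second, so it remains open whether an amine, a carboxylic acid or a longer alkyl chain at either aromatic carbon would give a step beyond the scatter. Also open, on these data alone, are the effects of replacing the amide hydrogen with a methyl group and of replacing the alkene linker with a saturated two-carbon chain.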